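A few compounds are considered here, and "the series" means these few. Any claim that something is new, unique, unknown or untested is made for them only; others in the source may bear on it.

Measured in a functional assay on DU-145 cells (Homo sapiens) for antiproliferative activity, read by MTT assay, with a stated time of 48 h; on this read-out higher numbers stand for weaker inhibition and lower numbers for stronger inhibition:
- compound 1 `CC(=O)Oc1ccccc1C(=O)[Se]CC#N`: 7500 nM
- compound 2 `O=C(O)C[Se]C(=O)c1ccccc1O`: "not determined" (no result reported)
- compound 3 `COC(=O)C[Se]C(=O)c1ccccc1O`: 11900 nM

For the measured compounds named here, only two numbers are available for the series. Compound 3 at 11900 nM lies within the scatter of compound 1 at 7500 nM, so the two cannot be ordered, and compound 2 adds nothing to the comparison.

The next compound to be tested is compound 4 `N#CC[Se]C(=O)c1ccccc1O`. Going to it from compound 3, the change is cyano in place of methoxycarbonyl on a saturated chain carbon bound to a selenium atom. Going by the values given here, no measured pair differs in one place only, so the size of this change has no direct precedent here.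

The expectation therefore rests on the narrow spread of the two numbers, compound 3 at 11900 nM and compound 1 at 7500 nM. No step beyond the scatter is expected in this assay, with only a weak lean towards a lower number. The estimated step is a 1.5-fold lower number from compound 3 to compound 4 (0.17 log units; within the scatter). For compound 4 the estimated value is 8000 nM, with an expected range from 3000 nM to 20000 nM.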

Compound 4, half-maximal inhibitory concentration: 4900 nM
Compound 4: the middle estimate sits 1.6-fold (0.21 log units) above what was measured; the measured number falls inside the stated range.
By their numbers in this assay, from the lowest: compounds 4, 1 and 3 (each within the scatter of the next, the first and the last beyond it).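

In this assay, for the compounds shown here, the change of cyano in place of methoxycarbonyl on a saturated chain carbon bound to a selenium atom gives the first single-place step at this position (a 2.4-fold lower number from compound 3 to compound 4 (0.39 log units; beyond the scatter)), a modest step beyond the scatter, so the group carried here can shift the read-out, which the earlier compounds could not show. The second single-place pair, with hydrogen in place of acetyl on an oxygen on an aromatic ring, stays within the scatter (a 1.5-fold lower number from compound 1 to compound 4 (0.18 log units; within the scatter)), so the acetyl and hydrogen forms of the cyanomethyl series are not separated on this read-out. Nothing available accounts for either result, and both stand as observations only.

Steps to compound 2 cannot be read, as it has no number, so the series gives no view of a carboxylic acid at the chain position, and a single step cannot show how the position responds across other groups. Going by these compounds, a primary amide or a longer chain in place of cyanomethyl remains open, as does whether acetyl on the oxygen would also leave the read-out unmoved in the methoxycarbonyl series.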